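This account rests on a few compounds, and the source may have more. Where it says the series, first, only, none or still open, it means among the compounds named here.

Working notes on the ester series around the shared core: compound 1 `O=C(Oc1cccc(F)c1)c1cc2cc([N+](=O)[O-])ccc2oc1=O`, compound 2 `O=C(Oc1cccc(Cl)c1)c1cc2cc([N+](=O)[O-])ccc2oc1=O` and compound 3 `O=C(Oc1cccc(Br)c1)c1cc2cc([N+](=O)[O-])ccc2oc1=O`. In a functional assay on HT-1080 cells (Homo sapiens), read by transwell migration, with a stated time of 24 h, tested at 1 uM (on this read-out lower numbers stand for a stronger effect and higher numbers for a weaker effect at the one concentration tested), compound 1 gives 53.6%, compound 2 gives 65.8% and compound 3 gives 35.2%, so compound 1 stands second highest of the three numbers. The measured steps are all halogen exchanges on the phenyl ester: a number 12.2 percentage points higher from compound 1 to compound 2 (beyond the scatter), a number 18.4 percentage points lower from compound 1 to compound 3 (beyond the scatter) and a number 30.6 percentage points lower from compound 2 to compound 3 (beyond the scatter). Compound 4 `CC(=O)NCc1ccc2oc(=O)c(C(=O)Oc3cccc(F)c3)cc2c1` differs from compound 1 in another part of the molecule: acetamidomethyl in place of nitro on an aromatic carbon. None of the three measured steps concerns this change, so they give no guide to its direction or size; the expected step of a number 1.4 percentage points higher from compound 1 to compound 4 (within the scatter) is therefore set near zero with a wide range. Compound 4 is estimated at 55%, between 25% and 85%.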

Compound 4, a percentage reported as activity, at one concentration (the size of the read-out at that concentration, not a potency): 65.6%
The estimate for compound 4 lay 10.6 percentage points below the measured number; measured number inside the range.
By their numbers in this assay, from the lowest: compound 3; then compound 1; then compounds 4 and 2 (each within the scatter of the next).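

In this assay the position on the shared core that carries nitro in compound 1 also moves the read-out: a number 12 percentage points higher from compound 1 to compound 4 (beyond the scatter) with acetamidomethyl in place of nitro, towards a weaker effect at the one concentration tested. The halogen exchanges on the phenyl ester did not touch this position, so the step is its first reading. No measurement shown bears on why the step takes this direction. Still open, as far as these compounds go, is how a primary amine, a carboxylic acid or a longer chain would behave at this position, and whether the step holds with bromo in place of fluoro on the phenyl ester.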